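The compounds below may be only part of what the source reports. "The series", "measured", "known", "first", "only" and "open" are said of these compounds alone.

Among the measured compounds shown here, compound 2 `O=C1COc2ccc(-c3cnc4ccccc4c3)cc2N1c1ccccc1` is one of three compounds measured in a functional assay on A-375 cells (Homo sapiens) for antiproliferative activity, read by MTT assay, with a stated time of 72 h; on this read-out lower numbers stand for stronger inhibition and higher numbers for weaker inhibition. In this assay compound 2 gives only a limit, > 40000 nM. Compound 1 `Cc1ccc(N2C(=O)COc3ccc(-c4cnc5ccccc5c4)cc32)cc1` gives only a limit in this assay as well, > 40000 nM. Compound 3 `COc1ncc(-c2ccc3c(c2)N(c2ccc(F)cc2)C(=O)CO3)cc1NS(=O)(=O)c1ccc(F)cc1`, which carries a different set of substituents on the shared core, also gives only a limit in this assay, > 40000 nM. For the measured compounds named here, the one step between measured compounds that differ in a single place, a step that the two limits leave unreadable from compound 1 to compound 2, is hydrogen in place of methyl on an aromatic carbon; both of its ends sit at the limit of > 40000 nM in this assay, at which 3 of the 3 values shown sit, so its size cannot be read. Compound 4 `COc1cccc(N2C(=O)COc3ccc(-c4cnc5ccccc5c4)cc32)c1` has not yet been measured. It differs from compound 2 by methoxy in place of hydrogen on an aromatic carbon, a change that, taken one bond further out, reads phenyl to 3-methoxyphenyl. Going by the values given here, no measured step shows what a methoxy group does here, and the nearest comparison, the methyl-to-hydrogen step, is unreadable. The step expected from compound 2 to compound 4 is therefore a number no higher from compound 2 to compound 4 (the limit leaves the size open), nothing beyond the scatter. Compound 4 is estimated at 40000 nM, within 10000 nM to 100000 nM, and is expected most likely to be reported again as a limit.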

Compound 4, half-maximal inhibitory concentration: 23600 nM
The estimate for compound 4 lay 1.7-fold (0.23 log units) above the measured number, and the stated range covers the measured number.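

In this assay compound 4, with 3-methoxyphenyl on the amide-type nitrogen, is the only compound shown to give a number rather than a limit: the limit of > 40000 nM in this assay, at which 3 of the 4 values shown sit.

Methoxy in place of hydrogen on the aromatic carbon gives an at least 1.6-fold lower number from compound 2 to compound 4 (0.22 log units; that floor lies within the scatter), and 3-methoxyphenyl in place of 4-methylphenyl gives an at least 1.6-fold lower number from compound 1 to compound 4 (0.22 log units; that floor lies within the scatter). Each step is a floor and not a size, so this position now has a lower bound on a change where the earlier step could not be read at all, but no real gain can be claimed from it.

The compounds shown leave open how far the true gap extends and whether methoxy elsewhere on that six-membered ring would read the same. They also leave open whether a hydroxy group, an amine or a carboxylic acid at this place would give a lower number.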